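A few compounds are considered here, and "the series" means these few. Any claim that something is new, unique, unknown or untested is made for them only; others in the source may bear on it.

In a functional assay on MT2 cells (Homo sapiens) for antiproliferative activity, read by MTT assay, with a stated time of 72 h (on this read-out higher numbers stand for weaker inhibition of growth and lower numbers for stronger inhibition of growth), three compounds have been measured. Compound 1 `O=C(COc1ccc2oc(-c3ccccc3)cc(=O)c2c1)Nc1ccc2ccccc2c1` is recorded at > 10000 nM, which is a limit of the assay and not a number. Compound 2 `O=C(COc1ccc2c(=O)c(-c3ccccc3)coc2c1)Nc1ccc2ccccc2c1` gives 7680 nM. Compound 3 `O=C(COc1ccc2oc(-c3ccccc3)cc(=O)c2c1)Nc1ccc(F)cc1` gives 470 nM, the lowest number of the three, and so shows the strongest inhibition of growth so far.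

Compound 4 `COc1ccc(NC(=O)COc2ccc3oc(-c4ccccc4)cc(=O)c3c2)cc1` differs from compound 3 in one place: methoxy in place of fluoro on an aromatic carbon. This puts methoxy in place of fluoro on an aromatic carbon, para to a large group. Within the data shown here, only one measured step touches this part of the molecule: an at least 21-fold lower number from compound 1 to compound 3 (1.32 log units; beyond the scatter), with 4-fluorophenyl in place of naphthalen-2-yl on an amide-type nitrogen. That large step shows that the group on this nitrogen matters, but it exchanges a whole group and does not test this smaller swap. The expected result is a much smaller move, a 1.7-fold higher number from compound 3 to compound 4 (0.23 log units; within the scatter), leaning towards a higher number with compound 3 starting from 470 nM. Compound 4 is estimated at 800 nM, with an expected range of 200 nM to 3000 nM.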

Compound 4, concentration for 50% growth inhibition: 3010 nM
Estimate against measurement, compound 4: 3.8-fold (0.58 log units) below; the measured number lies above the stated range.
By their numbers in this assay, from the lowest: compound 3; then compound 4; then compound 2. At a limit, above all of these: compound 1.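

In this assay, the earlier step exchanged a whole group on the amide-type nitrogen, whereas this one changes only fluoro to methoxy on the aromatic ring of that group and still gives a 6.4-fold higher number from compound 3 to compound 4 (0.81 log units; beyond the scatter). This position therefore responds to a small swap, not only to a change of the whole group, and 4-methoxyphenyl still compares well with naphthalen-2-yl, with an at least 3.3-fold lower number from compound 1 to compound 4 (0.52 log units; beyond the scatter). That second step gives only a bound, since compound 1 is recorded at a limit of the assay and not at a number: the limit of > 10000 nM in this assay, at which 1 of the 4 values shown sits.

On these data alone, two groups at one position cannot establish a trend, so it remains open where chloro, nitrile, an amine or plain hydrogen would fall. As far as these compounds go, it also remains open whether fluoro and methoxy would differ in the same way on the core of compound 2.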